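The source may hold more compounds than are shown below. What is called first, only, known or untested is meant among the compounds shown, and "the series" means these compounds.

Compound 1 `COc1cc(N(Cc2nc3ccccc3[nH]2)S(=O)(=O)c2ccc(C)cc2)cc(OC)c1OC` carries a (4-methylphenyl)sulfonyl on the nitrogen of the shared core, and in a functional assay on MCF7 cells (Homo sapiens) for inhibition, read by MTT assay, with a stated time of 48 h (a lower number here means a stronger inhibitor, a higher number a weaker inhibitor), compound 1 gives 5400 nM. Compound 2 `COc1cc(N(Cc2nc3ccccc3[nH]2)S(=O)(=O)c2ccc(Br)cc2)cc(OC)c1OC` has bromo in place of methyl on an aromatic carbon, and in this assay compound 2 gives 7740 nM, a change of a 1.4-fold higher number from compound 1 to compound 2 (0.16 log units; within the scatter). Compound 3 `COc1cc(N(Cc2nc3ccccc3[nH]2)C(=O)c2ccc(Br)cc2)cc(OC)c1OC` instead bears a (4-bromophenyl)carbonyl on that nitrogen. In this assay compound 3 reaches only the limit > 50000 nM, so no exact number is known for it. Against the sulfonyl compounds the steps were an at least 9.2-fold higher number from compound 1 to compound 3 (0.96 log units; beyond the scatter) and an at least 6.4-fold higher number from compound 2 to compound 3 (0.81 log units; beyond the scatter), which leaves compound 3 as the weakest of the three. Compound 4 `COc1ccc(C(=O)N(Cc2nc3ccccc3[nH]2)c2cc(OC)c(OC)c(OC)c2)cc1OC` keeps the carbonyl of compound 3 and differs only by 3,4-dimethoxyphenyl in place of 4-bromophenyl on a carbonyl carbon. Going by the values given here, no measured step alters the ring on the carbonyl; the nearest comparison is the ring substituent swap on the sulfonyl side, which stayed within the scatter. Therefore the expected step is a step that the limit leaves unreadable from compound 3 to compound 4, nothing beyond the scatter. Compound 4 is estimated to give 60000 nM in this assay, somewhere between 15000 nM and 250000 nM, most likely again reported only as a limit.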

Compound 4, half-maximal inhibitory concentration: > 50000 nM
Compound 4: only a limit was reported; the forecaster's own chance of this, stated with the estimate: 70%; the middle value is on the limit's open side.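

No step can be read between compound 3 and compound 4, because both reach only the same limit: the limit of > 50000 nM in this assay, at which 2 of the 4 values shown sit.

The compounds shown leave open what exact number either would give, and so whether 3,4-dimethoxyphenyl or 4-bromophenyl on the carbonyl carbon makes any difference.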